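The source may hold more compounds than are shown below. What is called first, only, known or untested is meant among the compounds shown, and "the series" means these compounds.

Of the compounds shown here, three have so far been tested in a functional assay on PC-12 cells (Rattus norvegicus) for cytotoxicity, read by MTT assay, with a stated time of 24 h, tested at 0.1 uM; on this read-out higher numbers stand for a stronger effect at the one concentration tested and lower numbers for a weaker effect. Compound 1, `O=C(COc1ccc2ccccc2c1)N1CCN(C(c2ccc(Br)cc2)c2ccc(Br)cc2)CC1`, gives 4.06% in this assay. Compound 3, `COc1ccc(OCC(=O)N2CCN(C(c3ccc(F)cc3)c3ccc(F)cc3)CC2)cc1`, gives 3.1%, and compound 2, `COc1ccc(C(c2ccc(OC)cc2)N2CCN(C(=O)COc3ccccc3C)CC2)cc1`, gives 2.45%. On the numbers shown compound 1 sits at the top of the three, but the number of compound 3 and that of compound 2 both lie within the usual scatter of repeated measurements of this kind, so the three cannot be told apart on this read-out and none can be called more active than another.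

Compound 4, `COc1ccc(OCC(=O)N2CCN(C(c3ccc(Br)cc3)c3ccc(Br)cc3)CC2)cc1`, has not yet been measured in this assay. It differs from compound 1 in one place: 4-methoxyphenyl in place of naphthalen-2-yl on an oxygen on a saturated carbon. For the measured compounds named here, no pair of measured compounds differs in a single place, so there is no measured step to lean on. Compound 3 already carries the 4-methoxyphenoxy group that enters here and gives a number close to that of compound 1, which suggests the ether part matters little on this read-out. The expected step is a number 1.1 percentage points lower from compound 1 to compound 4 (within the scatter), that is, none beyond the scatter in either direction. Compound 4 is accordingly expected to give about 3%, within a range from 0% to 8%.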

Compound 4, a percentage reported as activity, at one concentration (the size of the read-out at that concentration, not a potency): 3.52%
Compound 4: middle estimate off by 0.5 percentage points, on the low side; low and high end bracket the measured number.
By their numbers in this assay, from the lowest: compounds 2, 3, 4 and 1 (each within the scatter of the next).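

In this assay, placing 4-methoxyphenyl in place of naphthalen-2-yl on an oxygen on a saturated carbon gives a number 0.5 percentage points lower from compound 1 to compound 4 (within the scatter), and this is the first measured change in a single place among these compounds. At this position, then, going from two aromatic rings to one, with one hydrogen-bond acceptor entering, produces no change that can be told from the scatter on the core of compound 1. No independent measurement bears on this result, and the pair alone gives no explanation for it.

On these data alone, whether a different kind of group at this position, such as a primary amine or a carboxylic acid carried on a longer chain, would produce a step beyond the scatter remains open. As far as these compounds go, it is equally open whether the exchange of naphthalen-2-yl for 4-methoxyphenyl would read the same on a core other than that of compound 1, or at a concentration other than the single one used here.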